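The source may report more compounds than this note shows. Statements on the series, on what has been measured and on what is new or still open speak of the compounds shown alone.

Two urea compounds have been tested in a functional assay on Bel-7402 cells (Homo sapiens) for cytotoxicity, read by MTT assay, with a stated time of 72 h; a higher number here means a weaker inhibitor, a lower number a stronger inhibitor. Compound 1, `O=C(Nc1ccc(-n2ncc3c(C(F)(F)F)cccc32)cc1)Nc1ccc(Cl)c(C(F)(F)F)c1`, gives 16000 nM in this assay. Compound 2, `O=C(Nc1ccc(-n2ncc3c(F)cccc32)cc1)Nc1ccc(Cl)c(C(F)(F)F)c1`, carries fluoro in place of trifluoromethyl on an aromatic carbon of the shared core, and in this assay compound 2 gives 16000 nM. The step of no change at the digits printed from compound 1 to compound 2 (within the scatter) shows that this swap left the cytotoxicity unchanged, so compound 2 stands level with compound 1 and both are weak inhibitors.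

Compound 3, `Cc1cccc2c1cnn2-c1ccc(NC(=O)Nc2ccc(Cl)c(C(F)(F)F)c2)cc1`, is not yet measured. It differs from compound 2 in one place: methyl in place of fluoro on an aromatic carbon. Among the measured compounds shown here, the only step known here is the one from compound 1 to compound 2, which changed the same aromatic carbon and moved the number not at all. The new change is again a single heavy atom for a single heavy atom at that carbon. On this basis no step beyond the scatter is expected, and the change no change at the digits printed from compound 2 to compound 3 (within the scatter) is the estimate for the move in this assay. Compound 3 is therefore expected to give about 16000 nM in this assay, with a likely range from 6000 nM to 40000 nM.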

Compound 3, half-maximal inhibitory concentration: 6700 nM
Compound 3: middle estimate off by 2.4-fold (0.38 log units), on the high side, and the stated range covers the measured number.
By their numbers in this assay, from the lowest: compound 3; then compounds 1 and 2 (each within the scatter of the next).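

The earlier pair showed only that fluoro and trifluoromethyl sit level at this aromatic carbon, which could have meant that the number in this assay did not respond to changes here at all. Methyl shows that it does respond, though modestly: replacing fluoro gives a 2.4-fold lower number from compound 2 to compound 3 (0.38 log units; beyond the scatter) and replacing trifluoromethyl gives a 2.4-fold lower number from compound 1 to compound 3 (0.38 log units; beyond the scatter) (both steps are beyond the scatter), so among these three groups methyl alone stands apart, with the lowest number. Nothing measured here explains why methyl differs from the other two groups.

The three compounds cover just three small groups at one carbon, all on the same urea framework, so they cannot show whether the lower number belongs to methyl alone or would continue with a longer chain such as ethyl, or how an amine or a methoxy group would behave at this carbon. Going by these compounds, whether the same swap from fluoro to methyl would lower the number at another carbon of the shared core also remains open.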